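A few compounds are considered here, and "the series" means these few. Any claim that something is new, unique, unknown or untested is made for them only; others in the source may bear on it.

Compound 1 `NC(=O)c1c(NC(=O)c2ccccc2Cl)sc2c1CCN(C(=S)Nc1cccc3ccccc13)C2`: 13400 nM
Compound 2 `NC(=O)c1c(NC(=O)c2ccccc2Cl)sc2c1CCN(C(=S)Nc1ccccc1I)C2`: 4430 nM
Compound 3 `NC(=O)c1c(NC(=O)c2ccccc2)sc2c1CCN(C(=S)Nc1ccccc1Cl)C2`: 13800 nM

In a functional assay on HL-60 cells (Homo sapiens) for antiproliferative activity, with a stated time of 24 h (a higher number here means a weaker inhibitor, a lower number a stronger inhibitor), compound 3 gives 13800 nM, the highest of the three numbers; the gap to compound 1 lies within the scatter, whereas compound 2 gives a number beyond the scatter below it. Compound 4 `Cc1ccc(C(=O)Nc2sc3c(c2C(N)=O)CCN(C(=S)Nc2ccccc2Cl)C3)cc1` differs from compound 3 in one place: methyl in place of hydrogen on an aromatic carbon, which reads phenyl to 4-methylphenyl. Among the compounds with values here, the only measured step, a 3.0-fold lower number from compound 1 to compound 2 (0.48 log units; beyond the scatter), alters a different group at the other end of the shared core, so no measured step bears on this change. With nothing to guide a direction, the step of no change at the digits printed from compound 3 to compound 4 (within the scatter) is expected to stay within the scatter. Compound 4 is therefore estimated at 13800 nM, with a range from 5000 nM to 38000 nM.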

Compound 4, half-maximal inhibitory concentration: 8430 nM
Compound 4: the middle estimate sits 1.6-fold (0.21 log units) above what was measured, and the stated range covers the measured number.
By their numbers in this assay, from the lowest: compounds 2, 4, 1 and 3 (each within the scatter of the next, the first and the last beyond it).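

In this assay, methyl in place of hydrogen on the benzoyl ring gives a 1.6-fold lower number from compound 3 to compound 4 (0.21 log units; within the scatter), the first step measured at this end of the shared core. At this carbon, para to a large group, one added carbon therefore produces no change that can be told apart from the scatter. No measurement shown here offers an explanation for this result. Still open, as far as these compounds go, is whether a longer chain such as butyl, an amine or a carboxylic acid on the same carbon would give a step beyond the scatter.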